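A Trifluoromethyl Swap on the Carbonyl of Compound 2

The compounds below may be only part of what the source reports. "The series", "measured", "known", "first", "only" and "open" are said of these compounds alone.

Compound 1 `CNc1nc(C)c(C(=O)N/N=C/c2cccc(C(F)(F)F)c2)s1` gives only a limit in a functional assay on HeLa cells (Homo sapiens) for inhibition, read by MTT assay, with a stated time of 72 h (on this read-out higher numbers stand for weaker inhibition and lower numbers for stronger inhibition), reading > 100 ug/mL. That value is the limit of > 100 ug/mL in this assay, at which 1 of the 2 values shown sits. Compound 2 `CN(C(=O)NC(=O)c1ccc(F)c(F)c1)c1nc(C(F)(F)F)c(C(=O)N/N=C/c2cc(C(F)(F)F)cc(C(F)(F)F)c2)s1` gives 4.45 ug/mL in this assay, the only number shown in that assay. Compound 3 `CN(C(=O)NC(=O)c1cccc(C(F)(F)F)c1)c1nc(C(F)(F)F)c(C(=O)N/N=C/c2cc(C(F)(F)F)cc(C(F)(F)F)c2)s1` differs from compound 2 by 3-(trifluoromethyl)phenyl in place of 3,4-difluorophenyl on a carbonyl carbon. No step of this kind has been measured among the shown compounds, so the expected step is a 1.1-fold higher number from compound 2 to compound 3 (0.05 log units; within the scatter), no larger than the usual scatter in either direction. Compound 3 is accordingly estimated at 5 ug/mL in this assay, with a likely range from 2 ug/mL to 15 ug/mL.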

Compound 3, half-maximal inhibitory concentration: 5.34 ug/mL
The estimate for compound 3 lay 1.1-fold (0.03 log units) below the measured number, within the range that was stated.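

In this assay the first step measured at this position reads a 1.2-fold higher number from compound 2 to compound 3 (0.08 log units; within the scatter) and so, with 3-(trifluoromethyl)phenyl in place of 3,4-difluorophenyl on the carbonyl carbon, the two groups cannot be told apart on this read-out. This position therefore accepts this change without a measurable shift, a point that compound 1 alone could not show. Nothing shown explains this result. As far as these compounds go, what stays open is whether a phenyl carrying an amine or a carboxylic acid, or a saturated cyclohexyl ring, on this carbonyl carbon would also leave the number in place.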